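Removing the 4-chlorophenylcarbonyl group from compound 3

The source may report more compounds than this note shows. Statements on the series, on what has been measured and on what is new or still open speak of the compounds shown alone.

Measured compounds:
- compound 1, `COc1ccccc1NC(=O)C1NCCc2ccccc21`, in a functional assay on NUGC-3 cells (Homo sapiens) for inhibition, read by sulforhodamine B assay, with a stated time of 48 h (on this read-out higher numbers stand for weaker inhibition of growth and lower numbers for stronger inhibition of growth), gives > 10000 nM, a limit of the assay.
- compound 2, `O=C(Nc1cccc(O)c1)C1c2ccccc2CCN1C(=O)c1ccc(Cl)cc1`, in this assay gives > 10000 nM, a limit of the assay.
- compound 3, `O=C(Nc1ccccc1O)C1c2ccccc2CCN1C(=O)c1ccc(Cl)cc1`, in this assay gives > 10000 nM, a limit of the assay.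

Compound 3 stands only at a limit in this assay; no number was reached for it, and the same holds for the other two values shown (the limit of > 10000 nM in this assay, at which 3 of the 3 values shown sit). Going by the values given here, the one step that could be read here, a step that the two limits leave unreadable from compound 2 to compound 3, is left unreadable by the two limits.

Compound 4, `O=C(Nc1ccccc1O)C1NCCc2ccccc21`, differs from compound 3 by hydrogen in place of (4-chlorophenyl)carbonyl on an amine nitrogen in a ring. Among the compounds with values here, no measured step covers this change directly. Compound 1, which carries the same hydrogen on the ring nitrogen but a 2-methoxyphenyl group on the amide nitrogen, also sits at a limit in this assay, so both the compounds with and those without the (4-chlorophenyl)carbonyl group show no measurable growth inhibition. An expected step of no readable size, a step that the limit leaves unreadable from compound 3 to compound 4, follows for compound 4. Compound 4 is therefore estimated at 20000 nM in this assay, within 8000 nM to 100000 nM, most likely reported again only as a limit.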

Compound 4, concentration for 50% growth inhibition: > 10000 nM
Compound 4 gave a limit, no number; the forecaster's own chance of this, stated with the estimate: 85%; the middle value lies beyond the limit too.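

No new step can be read: the comparisons of compound 4 with compound 3 and with compound 1 have no readable size, as each compound gives only a limit, not a number. The compounds shown leave open whether any change to the shared core would give a measurable growth inhibition in this assay, and one limit holds throughout: the limit of > 10000 nM in this assay, at which 4 of the 4 values shown sit.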